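The source may report more compounds than this note shows. Statements on the series, on what has been measured and on what is new or still open speak of the compounds shown alone.

Measured so far in a functional assay on MCF7 cells (Homo sapiens) for cytotoxicity, read by MTT assay, with a stated time of 48 h; on this read-out higher numbers stand for weaker inhibition and lower numbers for stronger inhibition:
- compound 1 `CC(=O)Nc1cccc(-c2cnc3[nH]cc(-c4ccncc4)c3c2)c1`: 9100 nM
- compound 2 `Nc1cccc(-c2cnc3[nH]cc(-c4ccncc4)c3c2)c1`: 2300 nM

Within the data shown here, compound 2 stands lowest of the two numbers in this assay; compound 1 is its nearest neighbour, and the single measured step, a 4.0-fold lower number from compound 1 to compound 2 (0.60 log units; beyond the scatter), is modest but beyond the scatter. Compound 3 `COc1ccc(-c2cnc3[nH]cc(-c4ccncc4)c3c2)cc1N` differs from compound 2 by methoxy in place of hydrogen on an aromatic carbon. Among the measured compounds shown here, no measured step bears on this change: the only step known concerns the substituent on the amino nitrogen, not a new group on the ring. The expected step, a 1.2-fold lower number from compound 2 to compound 3 (0.06 log units; within the scatter), is therefore small, with no clear direction. Compound 3 is expected to give about 2000 nM in this assay, within 700 nM to 6000 nM.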

Compound 3, half-maximal inhibitory concentration: 8700 nM
Estimate against measurement, compound 3: 4.4-fold (0.64 log units) below, and the stated range ends below it.
By their numbers in this assay, from the lowest: compound 2; then compounds 3 and 1 (each within the scatter of the next).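

A change on the ring carbon, not only on the amino nitrogen, moves the number: in this assay methoxy in place of hydrogen, ortho to the amino group and para to a large group, brings a 3.8-fold higher number from compound 2 to compound 3 (0.58 log units; beyond the scatter) and so means weaker inhibition. Keeping the free amino group therefore does not protect against this loss. No measured property of the compounds accounts for the step.

From the compounds shown here alone, it remains open whether a fluorine atom or a hydroxy group on this carbon would weaken inhibition too, or whether the loss is particular to methoxy. Methoxy on another carbon of this ring could also behave differently.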